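The source may report more compounds than this note shows. Statements on the series, on what has been measured and on what is new or still open speak of the compounds shown alone.

In an ADME assay on the whole organism for cytotoxicity, with Artemia salina as the target, with a stated time of 24 h (a lower number here means that less compound is needed, a higher number that more compound is needed for the effect), the measured compounds are:
compound 1, `Cc1ccc(/C=C/C(=O)c2ccccc2NC(=O)NS(=O)(=O)c2ccc(C)cc2)cc1` — 15.3 ug/mL
compound 2, `Cc1ccc(S(=O)(=O)NC(=O)Nc2ccccc2C(=O)/C=C/c2ccccc2O)cc1` — 32.3 ug/mL
compound 3, `Cc1ccc(S(=O)(=O)NC(=O)Nc2ccccc2C(=O)/C=C/c2ccccc2[N+](=O)[O-])cc1` — 40.1 ug/mL

Compound 3 holds the highest of the three numbers; compound 2 sits within the scatter of it, while compound 1 lies clearly lower (a 2.6-fold higher number from compound 1 to compound 3 (0.42 log units; beyond the scatter)). The next compound, compound 4, `Cc1ccc(S(=O)(=O)NC(=O)Nc2ccccc2C(=O)/C=C/c2ccc(F)cc2)cc1`, carries the change (4-fluorophenyl in place of 2-nitrophenyl on a double-bonded chain carbon bound to a double-bonded chain carbon). Among the measured compounds shown here, the steps that bear on it are a 2.1-fold higher number from compound 1 to compound 2 (0.32 log units; beyond the scatter) and a 2.6-fold higher number from compound 1 to compound 3 (0.42 log units; beyond the scatter), both modest rises on leaving 4-methylphenyl; a 1.2-fold higher number from compound 2 to compound 3 (0.09 log units; within the scatter) adds nothing beyond the scatter. Since 4-fluorophenyl resembles the 4-methylphenyl of compound 1 more than the 2-nitrophenyl of compound 3, a modest fall is expected, a 2.0-fold lower number from compound 3 to compound 4 (0.30 log units; within the scatter). For compound 4 the expected value in this assay is 20 ug/mL, with a range of 10 ug/mL to 40 ug/mL.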

Compound 4, concentration for half-maximal effect: 3.96 ug/mL
Compound 4: middle estimate off by 5.1-fold (0.70 log units), on the high side; the measured number lies below the stated range.
By their numbers in this assay, from the lowest: compound 4; then compound 1; then compounds 2 and 3 (each within the scatter of the next).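

Among the compounds shown here, at this place, on a double-bonded chain carbon bound to a double-bonded chain carbon, 4-fluorophenyl gives the lowest number so far in this assay, with a 10-fold lower number from compound 3 to compound 4 (1.01 log units; beyond the scatter) and an 8.2-fold lower number from compound 2 to compound 4 (0.91 log units; beyond the scatter). Fluoro in place of methyl also gives a 3.9-fold lower number from compound 1 to compound 4 (0.59 log units; beyond the scatter), so the number can fall as well as rise from that of compound 1, where the earlier steps showed only rises. No measurement shown here accounts for this fall.

From the compounds shown here alone, whether the low number belongs to fluoro in particular stays open. Plain phenyl or 4-chlorophenyl at this place would help to settle that.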